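Adding 4-chlorobenzyl to compound 1: working notes

A few compounds are considered here, and "the series" means these few. Any claim that something is new, unique, unknown or untested is made for them only; others in the source may bear on it.

Of the compounds shown here, two have numbers so far. In a functional assay on HCT-116 cells (Homo sapiens) for inhibition, read by WST assay, with stated times of 72 h and 2 h (a higher number here means a weaker inhibitor, a lower number a stronger inhibitor), compound 1 `OC(c1cccs1)c1cc2ccccc2nc1Cl` gives 69300 nM as its half-maximal inhibitory concentration, and compound 2 `Cc1ccc(-c2cc(COC(c3cccs3)c3cc4ccccc4nc3Cl)on2)cc1` gives 115000 nM on the same read-out. These two values lie within the scatter of each other, so compound 1 stands level with compound 2 on the present numbers.

Compound 3 `Clc1ccc(COC(c2cccs2)c2cc3ccccc3nc2Cl)cc1` keeps the core of compound 1 and carries 4-chlorobenzyl in place of hydrogen on an oxygen on a saturated carbon, with 4-chlorobenzyl in place of hydrogen on an oxygen on a saturated carbon as the counted difference.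

Among the measured compounds shown here, no measured pair differing in one place exists yet, so the data offer no direct guide to this step. For the measured compounds named here, the only indication is that compound 2 at 115000 nM stays within the scatter of compound 1 at 69300 nM on this read-out. A step beyond the scatter is therefore not expected in this assay for this change. The estimated outcome is a 1.1-fold higher number from compound 1 to compound 3 (0.03 log units; within the scatter) with no firm direction. In this assay the estimate for compound 3 is 75000 nM with an expected range of 30000 nM to 150000 nM for a measurement.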

Compound 3, half-maximal inhibitory concentration: "not active" (no number reported)
Compound 3: no number reported; no gap can be computed for the estimate.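

Among the compounds shown here, compound 3 is reported as "not active" without a number in this assay, so no step from compound 1 to compound 3 can be read. No evidence at hand bears on this result. The compounds shown leave open how large a change, if any, 4-chlorobenzyl in place of hydrogen on that oxygen produces on this read-out.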